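A fluoro to bromo exchange in an antiproliferative test

The source may hold more compounds than are shown below. What is called first, only, known or untested is meant among the compounds shown, and "the series" means these compounds.

Of the compounds shown here, two built on a shared core have been measured in a functional assay on HeLa cells (Homo sapiens) for antiproliferative activity, read by MTT assay; a lower number here means a stronger inhibitor, a higher number a weaker inhibitor. Compound 1 (`Cc1cccc(Nc2nccc(-c3ccc(Br)cc3)n2)c1`) gives 71000 nM, and compound 2 (`COc1cccc(Nc2nccc(-c3ccc(F)cc3)n2)c1`) gives 145000 nM. Compound 2 therefore holds the higher of the two numbers, which makes it the weaker inhibitor of the pair, and the gap lies beyond the usual scatter.

Compound 3 (`COc1cccc(Nc2nccc(-c3ccc(Br)cc3)n2)c1`) has not yet been measured. It departs from compound 2 in one place, with bromo in place of fluoro on an aromatic carbon, the 4-fluorophenyl becoming 4-bromophenyl: bromo in place of fluoro on an aromatic carbon. Among the measured compounds shown here, no measured pair isolates this change, so the expectation rests on thin evidence. For the measured compounds named here, its only support is compound 1, which carries the same 4-bromophenyl group and reads 71000 nM. A modest move towards a lower number is expected, near the edge of the scatter or a little beyond it. The expected step is a 1.7-fold lower number from compound 2 to compound 3 (0.23 log units; within the scatter). For compound 3 the estimated value is 85000 nM, with an expected range from 35000 nM to 170000 nM.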

Compound 3, half-maximal inhibitory concentration: 153000 nM
Beside the measured number, compound 3's estimate is 1.8-fold (0.26 log units) below it, within the range that was stated.
By their numbers in this assay, from the lowest: compound 1; then compounds 2 and 3 (each within the scatter of the next).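

In this assay, the exchange of fluoro for bromo, the 4-fluorophenyl becoming 4-bromophenyl, now has a measured pair of its own. It reads a 1.1-fold higher number from compound 2 to compound 3 (0.02 log units; within the scatter), so with methoxy held fixed on the other aromatic ring, this position does not tell the two halogens apart. With the 4-bromophenyl group held fixed instead, the second new pair reads a 2.2-fold higher number from compound 1 to compound 3 (0.33 log units; beyond the scatter), a modest step for methoxy in place of methyl on an aromatic carbon, and of the two single changes now read, only this one lies beyond the scatter. Nothing available speaks to why either step has the size it has.

The compounds shown leave open whether fluoro and bromo also read alike when methyl takes the place of methoxy, and whether an amine or a carboxylic acid in place of the halogen would move the number at all. They also leave open whether a longer chain such as ethoxy would extend the step seen between methyl and methoxy or reverse it.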